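This account rests on a few compounds, and the source may have more. Where it says the series, first, only, none or still open, it means among the compounds named here.

Compound 1 `COc1ccc(-n2cc(/C=[N+](\[O-])Cc3ccccc3)nn2)cc1` and compound 2 `[O-]/[N+](=C\c1cn(-c2ccc(C(F)(F)F)cc2)nn1)Cc1ccccc1` share a core that carries an aryl group on the triazole nitrogen and a benzyl group on the nitrone nitrogen. In a functional assay on COLO 205 cells (Homo sapiens) for inhibition, read by MTT assay, with a stated time of 24 h (on this read-out lower numbers stand for stronger inhibition and higher numbers for weaker inhibition), compound 1 gives > 100000 nM, which is a limit of the assay rather than a number. In this assay compound 2 likewise gives > 100000 nM, again a limit of the assay. Among the measured compounds shown here, the step from compound 1 to compound 2, a step that the two limits leave unreadable from compound 1 to compound 2, therefore cannot be read, and the only evidence on the measured compounds is the limit of > 100000 nM in this assay, at which 2 of the 2 values shown sit, which places both of them at the same limit. Compound 3 `CC(C)(C)/[N+]([O-])=C/c1cn(-c2ccc(C(F)(F)F)cc2)nn1` differs from compound 2 by tert-butyl in place of benzyl on a double-bonded nitrogen. For the measured compounds named here, no measured step touches the group on the double-bonded nitrogen, so the change from benzyl to tert-butyl has no precedent here, and the shared limit of compound 1 and compound 2 gives no scale for it. The expectation for compound 3 is an inactive result close to the same limit, with the step from compound 2 to compound 3 estimated as a step that the limit leaves unreadable from compound 2 to compound 3. In this assay compound 3 is expected to give about 150000 nM, within a range from 30000 nM to 1000000 nM.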

Compound 3, half-maximal inhibitory concentration: 44700 nM
Compound 3: the middle estimate sits 3.4-fold (0.53 log units) above what was measured, within the range that was stated.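

Among the compounds shown here, changing the group on the double-bonded nitrogen is the first change here that moves the read-out by a readable amount: tert-butyl in place of benzyl gives an at least 2.2-fold lower number from compound 2 to compound 3 (0.34 log units; beyond the scatter) in this assay, a step beyond the scatter, whereas the step between compound 1 and compound 2 cannot be read. For the compounds shown here, this position therefore affects the result, and the group that enters, with no ring and fewer heavy atoms than benzyl, gives the only number in the set, though the effect is modest in what can be read and compound 3 remains weak at 44700 nM. The true size of the step stays unknown, since only a lower bound can be given while the starting point is a limit of the assay and not a number: the limit of > 100000 nM in this assay, at which 2 of the 3 values shown sit.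

As far as these compounds go, it remains open whether cyclohexyl, a straight butyl chain or an amine on the double-bonded nitrogen would behave like tert-butyl or like benzyl, and so whether the branched chain or the absence of the aromatic ring matters here. From the compounds shown here alone, it also remains open whether methoxy in place of trifluoromethyl on an aromatic carbon would change the read-out when tert-butyl sits on the double-bonded nitrogen.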